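The compounds below may be only part of what the source reports. "The series", "measured", "known", "first", "only" and "open" are said of these compounds alone.

For the measured compounds named here, in a functional assay on NALM-6 cells (Homo sapiens) for cytotoxicity, read by luminescence and CellTiter-Glo, with a stated time of 3 days (on this read-out higher numbers stand for weaker inhibition and lower numbers for stronger inhibition), compound 3 (`N#Cc1ccc(NC(=O)c2ccc3cccnc3c2O)cc1`) gives 130 nM and holds the lowest of the three numbers so far. Compound 1 (`N#Cc1ccc(NC(=O)c2ccc3cccnc3c2O)c(F)c1`) stands at 370 nM and compound 2 (`O=C(Nc1ccc(Cl)cc1Cl)c1ccc2cccnc2c1O`) at 450 nM on this read-out, two values within the scatter of each other. Compound 4 (`N#Cc1ccc(NC(=O)c2ccc3cccnc3c2O)c(Cl)c1`) has not yet been measured, and the change that leads to it from compound 3 is chloro in place of hydrogen on an aromatic carbon with chloro in place of hydrogen on an aromatic carbon. Going by the values given here, one measured step bears on this: a 2.8-fold lower number from compound 1 to compound 3 (0.45 log units; beyond the scatter) as hydrogen takes the place of fluoro on that same aromatic carbon. Read in reverse, that modest step ties fluoro there to a higher number, and compound 4 carries chloro where compound 1 carries fluoro. Among the compounds with values here, compound 2 also bears chloro, but no single-place step links it to compound 3, and no measured compound combines chloro with the nitrile. The size of the change therefore stays uncertain, yet a rise of similar modest size is expected in this assay rather than a fall. The expected step is a 2.9-fold higher number from compound 3 to compound 4 (0.47 log units; beyond the scatter) on this estimate. For compound 4 the estimated value is 380 nM with an expected range from 170 nM to 850 nM around it.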

Compound 4, half-maximal inhibitory concentration: 420 nM
Compound 4: middle estimate off by 1.1-fold (0.04 log units), on the low side; measured number inside the range.
By their numbers in this assay, from the lowest: compound 3; then compounds 1, 4 and 2 (each within the scatter of the next).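

In this assay the hydrogen of compound 3 on this aromatic carbon, ortho to a large group and meta to a cyano group, gives way to chloro with a 3.2-fold higher number from compound 3 to compound 4 (0.51 log units; beyond the scatter) and so the higher number seen with fluoro at this place now appears with a second halogen. Chloro in place of fluoro at the same carbon gives a 1.1-fold higher number from compound 1 to compound 4 (0.06 log units; within the scatter) and this places the two halogens within the scatter of each other, so in these compounds the rise from hydrogen does not depend on which of the two is present. With chloro held at this place, cyano in place of chloro on the other substituted aromatic carbon gives a 1.1-fold lower number from compound 2 to compound 4 (0.03 log units; within the scatter) and so this exchange, too, leaves the number within the scatter.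

On these data alone, whether the rise follows any group larger than hydrogen at this carbon or belongs to the halogens alone stays open, and a methoxy group, an amine or a carboxylic acid there would separate these two readings. The compounds shown come with no measurement that would account for the rise seen with fluoro and chloro.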